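From cyclohexylmethoxy to phenoxy: an expected small step

A few compounds are considered here, and "the series" means these few. Any claim that something is new, unique, unknown or untested is made for them only; others in the source may bear on it.

Measured so far in a functional assay on MCF7 cells (Homo sapiens) for antiproliferative activity, read by sulforhodamine B assay, with a stated time of 3 days; on this read-out higher numbers stand for weaker inhibition and lower numbers for stronger inhibition:
Compound 1 `O=c1ccn(C2COc3ccccc3CO2)c(=O)[nH]1` gives 5000 nM
Compound 2 `c1ccc2c(c1)COC(n1cnc3c(OCC4CCCCC4)ncnc31)CO2` gives 11600 nM

Compound 2 holds the higher of the two numbers, so its inhibition is the weaker of the pair, and its gap to compound 1 lies beyond the usual scatter. Compound 3 `c1ccc(Oc2ncnc3c2ncn3C2COc3ccccc3CO2)cc1` keeps the core of compound 2 and alters one group. The change is phenyl in place of cyclohexylmethyl on an oxygen on an aromatic ring which in words is phenyl in place of cyclohexylmethyl on an oxygen on an aromatic ring, or cyclohexylmethoxy to phenoxy. Among the measured compounds shown here, no pair of measured compounds shows what such a change does in this assay so only a small step is expected, towards slightly stronger inhibition and possibly none beyond the scatter. The expected move is a 1.3-fold lower number from compound 2 to compound 3 (0.11 log units; within the scatter) as an estimate only. Compound 3 is estimated at 9000 nM with an expected range from 3000 nM to 27000 nM in this measurement.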

Compound 3, half-maximal inhibitory concentration: 24700 nM
Beside the measured number, compound 3's estimate is 2.7-fold (0.44 log units) below it, within the range that was stated.
By their numbers in this assay, from the lowest: compound 1; then compound 2; then compound 3.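

In this assay, among the compounds shown here, the change from cyclohexylmethoxy to phenoxy brings a 2.1-fold higher number from compound 2 to compound 3 (0.33 log units; beyond the scatter) and gives the first measured step at this place, an oxygen on an aromatic ring. The group carried on that oxygen therefore affects the read-out, and on this core phenyl goes with weaker inhibition than cyclohexylmethyl. An aromatic ring at this place thus offers no gain over the non-aromatic ring of compound 2 in this comparison. Nothing available accounts for the rise in the number.

This single step changes two things at once, the ring type and the carbon link between ring and oxygen, so it cannot show which of them matters. A benzyl or cyclohexyl group on the same oxygen would separate the two, and an amine in place of that oxygen would test the linking atom itself.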